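Replacing the methylcarbamoyl group of compound 3 with fluoro

The source may report more compounds than this note shows. Statements on the series, on what has been measured and on what is new or still open speak of the compounds shown alone.

Measured so far in a functional assay on NCI-H1975 cells (Homo sapiens) for antiproliferative activity, read by CCK-8 assay, with a stated time of 72 h; a lower number here means a stronger inhibitor of growth, a higher number a weaker inhibitor of growth
- compound 1 `CCC1C(=O)N(C)c2cnc(-n3ccc4cc(C(=O)NC(C)C)ccc43)nc2N1c1ccn(C)n1` gives 12200 nM
- compound 2 `CCC1C(=O)N(C)c2cnc(Nc3ccc(S(=O)(=O)NCCO)cc3)nc2N1c1ccn(C)n1` gives "not active" (no number reported)
- compound 3 `CCC1C(=O)N(C)c2cnc(-n3ccc4cc(C(=O)NC)ccc43)nc2N1c1ccn(C)n1` gives 35700 nM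

Compound 3 at 35700 nM is the higher of the two numbers, and compound 2 gives none. Compound 4 `CCC1C(=O)N(C)c2cnc(-n3ccc4cc(F)ccc43)nc2N1c1ccn(C)n1` differs by fluoro in place of methylcarbamoyl on an aromatic carbon in one place, fluoro in place of methylcarbamoyl on an aromatic carbon. Going by the values given here, the one measured step touching this amide is a 2.9-fold higher number from compound 1 to compound 3 (0.47 log units; beyond the scatter) and it is modest. Among the compounds with values here, no measured step removes the amide, so the data fix neither size nor direction. An expected 1.4-fold lower number from compound 3 to compound 4 (0.15 log units; within the scatter) is therefore no more than a cautious working figure. For compound 4 an estimate of 25000 nM is expected, within 8000 nM to 70000 nM as its range.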

Compound 4, concentration for 50% growth inhibition: 28600 nM
For compound 4 the middle estimate is 1.1-fold (0.06 log units) below the measured one; low and high end bracket the measured number.
By their numbers in this assay, from the lowest: compound 1; then compounds 4 and 3 (each within the scatter of the next).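

In this assay, the step of a 1.2-fold lower number from compound 3 to compound 4 (0.10 log units; within the scatter) shows that the methylcarbamoyl group offers no measurable gain over fluoro at this aromatic carbon, while the step of a 2.3-fold higher number from compound 1 to compound 4 (0.37 log units; beyond the scatter) sets the isopropylcarbamoyl group apart from fluoro. Among these three groups, only the isopropylcarbamoyl group separates from the others here. No measurement at hand explains this.

From the compounds shown here alone, whether a longer chain or a cyclohexyl group on the amide nitrogen would lower the number further remains open. So does the effect of an amine or a carboxylic acid on this carbon.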